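This account rests on a few compounds, and the source may have more. Where it says the series, first, only, none or still open, it means among the compounds named here.

Working notes on the series. Three compounds have numbers in an assay on microsomes from liver for inhibition of sterol O-acyltransferase 1 (Rattus norvegicus); a higher number here means a weaker inhibitor, a lower number a stronger inhibitor. Compound 1 `COc1cccc(-c2nc(SCC3C[C@](C)(O)CC(=O)O3)[nH]c2-c2cccc(OC)c2)c1` gives 570 nM in this assay. Compound 2 `Cn1c(SC[C@H]2C[C@@](C)(O)CC(=O)O2)nc(-c2ccccc2)c1-c1ccccc1.Cn1c(SC[C@H]2C[C@](C)(O)CC(=O)O2)nc(-c2ccccc2)c1-c1ccccc1` gives 2600 nM in this assay. Compound 3 `CC1=CC(=O)OC(CSc2nc(-c3ccccc3)c(-c3ccccc3)[nH]2)C1` gives 200 nM in this assay, the lowest of the three numbers; the gap to compound 1 and the larger gap to compound 2 both lie beyond the scatter, so compound 3 is the strongest inhibitor of the three shown.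

Compound 4 `CCOC(CCSc1nc(-c2ccccc2)c(-c2ccccc2)[nH]1)OCC` is not yet measured. Compared with compound 3, the change is a group of 8 heavy atoms (6 carbon, 2 oxygen; no ring) in place of a group of 8 heavy atoms (6 carbon, 2 oxygen; one six-membered non-aromatic ring with 1 hetero atom), on a saturated chain carbon bound to a sulfur. Among the measured compounds shown here, no step between two measured compounds covers a change of this kind, so nothing in the present numbers shows how this assay responds to it; the two closest analogues, compound 1 and compound 2, differ from compound 3 at other places as well.

For compound 4 the step of a 4.0-fold higher number from compound 3 to compound 4 (0.60 log units; beyond the scatter) is expected to be a modest move toward a weaker inhibitor, somewhat beyond the scatter. The estimate for compound 4 in this assay is 800 nM, within a range from 250 nM to 2500 nM.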

Compound 4, half-maximal inhibitory concentration: 69 nM
The estimate for compound 4 lay 12-fold (1.06 log units) above the measured number; measured number below the stated range.
By their numbers in this assay, from the lowest: compound 4; then compound 3; then compound 1; then compound 2.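

In this assay, among the compounds shown here, the first readable change on this saturated chain carbon bound to a sulfur gives a 2.9-fold lower number from compound 3 to compound 4 (0.46 log units; beyond the scatter) and shows that, on this core, the six-membered non-aromatic ring is not needed for the lower number. The 2,2-diethoxyethyl group matches the group it replaces in heavy atoms, carbon, oxygen, donors and acceptors, so the step goes with the loss of the ring and of the double bonds outside aromatic rings, and this single pair cannot separate those two. No measurement shown bears on the reason for the step. On these data alone, whether an amine, a carboxylic acid or a plain longer chain on the same carbon would keep the number low remains open. So does whether the 2,2-diethoxyethyl group gives a similar step on the cores of compound 1 and compound 2.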